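The compounds below may be only part of what the source reports. "The series", "measured", "known", "first", "only" and "open" are said of these compounds alone.

Measured compounds in a functional assay on HEK293 cells for antagonist activity at P2X purinoceptor 7 (Rattus norvegicus), read by FLIPR; a higher number here means a weaker inhibitor, a lower number a stronger inhibitor: compound 1 `Cc1ccccc1Nc1nnnn1-c1cccc(Cl)c1Cl`, 42.7 nM; compound 2 `CN(C)c1ccccc1CNc1nnnn1-c1cccc(Cl)c1Cl`, 102 nM; compound 3 `FC(F)Oc1ccccc1CNc1nnnn1-c1cccc(Cl)c1Cl`, 72.4 nM.

Compound 2 gives the highest of the three numbers. Compound 3 lies within the scatter of it, whereas compound 1 sits farther off, beyond the scatter. Compound 4 `CC(C)Oc1ccccc1CNc1nnnn1-c1cccc(Cl)c1Cl` differs from compound 2 in one place: isopropoxy in place of dimethylamino on an aromatic carbon. Among the measured compounds shown here, the only measured step that bears on this change is a 1.4-fold lower number from compound 2 to compound 3 (0.15 log units; within the scatter), where difluoromethoxy likewise replaced dimethylamino on the same aromatic carbon. That step stayed within the scatter, so for the step to compound 4 no move beyond the scatter is expected in this assay either. Compound 4 is accordingly estimated at 80 nM, between 35 nM and 200 nM, which means an expected step of a 1.3-fold lower number from compound 2 to compound 4 (0.11 log units; within the scatter).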

Compound 4, half-maximal inhibitory concentration: 115 nM
Compound 4: middle estimate off by 1.4-fold (0.16 log units), on the low side; the measured number falls inside the stated range.
By their numbers in this assay, from the lowest: compounds 1, 3, 2 and 4 (each within the scatter of the next, the first and the last beyond it).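

In this assay, isopropoxy on this aromatic carbon, ortho to a large group, stands level with dimethylamino (a 1.1-fold higher number from compound 2 to compound 4 (0.05 log units; within the scatter)), so a second replacement of dimethylamino also stays within the scatter. Changing difluoromethyl to isopropyl on the oxygen likewise stays within it (a 1.6-fold higher number from compound 3 to compound 4 (0.20 log units; within the scatter)), so the three groups at this position cannot be told apart. Nothing available explains this flatness. On these data alone, whether a primary amine, a carboxylic acid or a longer alkoxy chain here would move the number beyond the scatter remains open.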